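A smaller five-membered ring on the shared core

The source may hold more compounds than are shown below. What is called first, only, known or untested is meant among the compounds shown, and "the series" means these compounds.

Compound 1, `COc1ccc2[nH]c(-c3ccc[se]3)cc(=O)c2c1OC`: in an ADME assay on Detroit 551 cells (Homo sapiens) for cytotoxicity, read by MTT assay, with a stated time of 48 h (a lower number here means a stronger inhibitor, a higher number a weaker inhibitor), compound 1 gives > 100000 nM, which is a limit of the assay.
Compound 2, `COc1ccc2[nH]c(-c3ccc(C)[se]3)cc(=O)c2c1OC`: in this assay compound 2 gives > 50000 nM, likewise a limit.

Compound 2 thus stands only at a limit in this assay, and so does compound 1. The step that the two limits leave unreadable from compound 1 to compound 2 cannot be read because compound 1 sits at the limit of > 100000 nM in this assay, at which 1 of the 2 values shown sits, and compound 2 at the limit of > 50000 nM in this assay, at which 1 of the 2 values shown sits. Compound 3, `COc1ccc2[nH]c(-c3cc[se]c3)cc(=O)c2c1OC`, differs from compound 2 by a group of 5 heavy atoms (4 carbon, 1 selenium; one five-membered aromatic ring with 1 hetero atom) in place of a group of 6 heavy atoms (5 carbon, 1 selenium; one five-membered aromatic ring with 1 hetero atom), on an aromatic carbon. Within the data shown here, no measured step bears on this change, and the single step that exists gives no readable size or direction. Compound 3 is therefore expected to stay weak in this assay, with the step that the limit leaves unreadable from compound 2 to compound 3 expected to lie within the scatter. The estimate for compound 3 in this assay is 90000 nM, between 30000 nM and 300000 nM, and most likely it will again be reported only as a limit.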

Compound 3, half-maximal inhibitory concentration: > 100000 nM
Compound 3 ended at the assay's limit; the forecaster's own chance of this, stated with the estimate: 80%; middle value at least 1.1-fold (0.04 log units) from the limit.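

Among these compounds, compound 1, compound 2 and compound 3 all stand at limits in this assay, and no step among them can be read. The compounds shown leave open at what concentration any of them would reach half-maximal inhibition, and whether changing the five-membered aromatic ring shifts that concentration at all.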